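Anilino-pyrimidine series: growth inhibition in liver cells

A few compounds are considered here, and "the series" means these few. Any claim that something is new, unique, unknown or untested is made for them only; others in the source may bear on it.

Measured compounds:
- compound 1, `Cc1ccccc1Nc1nc(Nc2ccc(N3CCNCC3)cn2)ncc1Cl`: 1850 nM
- compound 2, `CCN1CCN(c2ccc(Nc3ncc(Cl)c(Nc4ccccc4C)n3)cc2)CC1`: 970 nM
- compound 3, `CN1CCN(c2ccc(Nc3ncc(Cl)c(NCc4ccc(F)cc4)n3)nc2)CC1`: 39700 nM

All three were run in an ADME assay on L02 cells (Homo sapiens) for inhibition, read by CCK-8 assay, with a stated time of 48 h; on this read-out lower numbers stand for stronger inhibition of growth and higher numbers for weaker inhibition of growth. Compound 3 gives 39700 nM, the highest number of the three, and thus the weakest inhibition of growth seen so far. Its nearest neighbour on the numbers is compound 1, which gives 1850 nM; the gap is well beyond the usual scatter. Compound 2 stands furthest away, with 970 nM, again beyond the scatter. Both compound 1 and compound 2 carry an aromatic ring directly on the amine nitrogen of the shared core, whereas compound 3 carries a benzyl group there.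

The next compound, compound 4, `CN1CCN(c2ccc(Nc3ncc(Cl)c(Nc4ccc(C(C)(C)C)cc4)n3)nc2)CC1`, is not yet measured. It differs from compound 3 in one place: 4-(tert-butyl)phenyl in place of 4-fluorobenzyl on a nitrogen on an aromatic ring. With this change compound 4 joins compounds 1 and 2 in bearing an aromatic ring directly on that nitrogen.

Expectation: the step from compound 3 to compound 4 in this assay is estimated at an 11-fold lower number from compound 3 to compound 4 (1.05 log units; beyond the scatter), a move toward lower numbers, because compound 1 gives 1850 nM and compound 2 gives 970 nM with an aryl group in the same place. Compound 4 is expected to give about 3500 nM, within a range from 900 nM to 14000 nM.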

Compound 4, concentration for 50% growth inhibition: 6070 nM
Compound 4: the middle estimate sits 1.7-fold (0.24 log units) below what was measured; measured number inside the range.
By their numbers in this assay, from the lowest: compounds 2 and 1 (each within the scatter of the next); then compound 4; then compound 3.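

In this assay, among these compounds, 4-(tert-butyl)phenyl in place of 4-fluorobenzyl on a nitrogen on an aromatic ring gives a 6.5-fold lower number from compound 3 to compound 4 (0.82 log units; beyond the scatter), the first comparison in which only this position changes. The size of the step shows that this position alone can shift growth inhibition in liver cells beyond the scatter, with the rest of compound 3 held constant. Among the compounds shown here, the single change alters both how the ring is attached and what the ring carries, and no measurement at hand bears on the reason for the step.

The contributions of the attachment and the tert-butyl group remain unseparated; a plain phenyl group or a fluorophenyl group at this nitrogen would divide them. Also open, from the compounds shown here alone, is how this position responds to rings carrying an amine or a carboxylic acid.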